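Benzylsulfanyl in place of amino at the shared core

This account rests on a few compounds, and the source may have more. Where it says the series, first, only, none or still open, it means among the compounds named here.

Compound 3 `Nc1nc2c(Cl)c(Cl)ccc2n1COC(CO)CO` is the starting point. In a functional assay on KB cells (Homo sapiens) for inhibition (on this read-out higher numbers stand for weaker inhibition and lower numbers for stronger inhibition), compound 3 reaches only the limit > 100000 nM, not a number. Compound 1 `CN(C)c1nc2cc(Cl)c(Cl)cc2n1COC(CO)CO` also gives only the limit > 100000 nM in this assay. Compound 2 `OCC(CO)OCn1cnc2cc(Cl)c(Cl)cc21` likewise gives only the limit > 100000 nM. The whole measured set thus sits at the limit of > 100000 nM in this assay, at which 3 of the 3 values shown sit. For the measured compounds named here, the single change between measured compounds, a step that the two limits leave unreadable from compound 1 to compound 2, cannot be sized. Compound 4 `OCC(CO)OCn1c(SCc2ccccc2)nc2c(Cl)c(Cl)ccc21` carries benzylsulfanyl in place of amino on an aromatic carbon. Going by the values given here, no measured step involves a benzylsulfanyl group, so nothing measured bears on this change. The step the estimate implies is expected to be an at least 1.2-fold lower number from compound 3 to compound 4 (0.09 log units; that floor lies within the scatter), with a limit again the likeliest outcome. Compound 4 is therefore expected at 80000 nM in this assay, within 10000 nM to 300000 nM.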

Compound 4, half-maximal inhibitory concentration: 60000 nM
Estimate against measurement, compound 4: 1.3-fold (0.12 log units) above; the measured number falls inside the stated range.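

This position, between two ring nitrogen atoms, now yields a readable number: in this assay compound 4 gives 60000 nM. Benzylsulfanyl in place of amino gives an at least 1.6-fold lower number from compound 3 to compound 4 (0.22 log units; that floor lies within the scatter), so the change has only a floor and its true size stays unknown. The remaining compounds offer no number for comparison: the limit of > 100000 nM in this assay, at which 3 of the 4 values shown sit.

Open, from the compounds shown here alone, is whether a methylsulfanyl or a benzylamino group at this position also gives a number. Also open, going by these compounds, is whether the step belongs to the sulfur or to the aromatic ring of benzylsulfanyl.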